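Trimming the amide chain on the shared core

The compounds below may be only part of what the source reports. "The series", "measured", "known", "first", "only" and "open" are said of these compounds alone.

Two compounds have so far been measured in an assay for inhibition of serine/threonine-protein kinase PLK2 (Homo sapiens), read by FRET and Z'-LYTE, with a stated time of 1 h; on this read-out lower numbers stand for stronger inhibition and higher numbers for weaker inhibition:

Compound 1, `CCC1C(=O)N(C)c2cnc(-n3ccc4cc(C(=O)NC)ccc43)nc2N1c1ccn(C)n1`, gives 218 nM.
Compound 2, `CCCCNC(=O)c1ccc2c(ccn2-c2ncc3c(n2)N(c2ccn(C)n2)C(CC)C(=O)N3C)c1`, gives 159 nM.

Compound 2 holds the lower of the two numbers, but only just: the step of a 1.4-fold lower number from compound 1 to compound 2 (0.14 log units; within the scatter) lies within the scatter of repeated measurements, so the two compounds cannot be told apart on these data.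

Compound 3, `CCC1C(=O)N(C)c2cnc(-n3ccc4cc(C(N)=O)ccc43)nc2N1c1ccn(C)n1`, is the next compound to be tested. It differs from compound 2 in a single place: hydrogen in place of butyl on an amide-type nitrogen. The amide that carried a butyl chain in compound 2 thus carries none in compound 3.

Among the measured compounds shown here, only one measured step bears on this change, the one from a methyl amide to a butyl amide, a 1.4-fold lower number from compound 1 to compound 2 (0.14 log units; within the scatter), and it did not move the number beyond the scatter. Lengthening the chain did little, so removing it is also expected to do little. The expected step is a 1.6-fold higher number from compound 2 to compound 3 (0.20 log units; within the scatter), with no direction that can be trusted. The estimated value for compound 3 is therefore 250 nM, with a likely range from 110 nM to 600 nM.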

Compound 3, half-maximal inhibitory concentration: 384 nM
For compound 3 the middle estimate is 1.5-fold (0.19 log units) below the measured one, within the range that was stated.
By their numbers in this assay, from the lowest: compounds 2, 1 and 3 (each within the scatter of the next, the first and the last beyond it).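

Taking the butyl chain off entirely does register: the change gives a 2.4-fold higher number from compound 2 to compound 3 (0.38 log units; beyond the scatter) and is the first step in this short series to lie beyond the scatter, so in this assay what sits on this amide nitrogen can make a real, if modest, difference. The methyl amide of compound 1 does not separate from either neighbour, since a 1.8-fold higher number from compound 1 to compound 3 (0.25 log units; within the scatter) is also within the scatter, which means that only the two ends of the set, hydrogen and butyl, can be told apart, and a single methyl on this nitrogen shows no measurable effect of its own. Nothing in the data explains why the butyl amide and the unsubstituted amide differ.

On these data alone, with only hydrogen, methyl and butyl on this nitrogen, it remains open whether a longer chain such as octyl would lower the number further or whether the gain stops at butyl. Also open, as far as these compounds go, is how a chain ending in an amine or a carboxylic acid, or a cyclohexyl ring in the same place, would compare with the plain butyl chain on the shared core.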